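Carboxylic Acid to Carboxamide on a Shared Core

The source may hold more compounds than are shown below. What is called first, only, known or untested is meant among the compounds shown, and "the series" means these compounds.

Measured in an assay for binding affinity to dual specificity mitogen-activated protein kinase kinase 4 (Homo sapiens), read by KINOMEscan, tested at 10 nM; on this read-out higher numbers stand for a weaker effect at the one concentration tested and lower numbers for a stronger effect:
compound 1, `CCCS(=O)(=O)Nc1ccc(F)c(C(=O)c2n[nH]c3ncc(-c4ccc(S(N)(=O)=O)cc4)cc23)c1F`, gives 5.1%
compound 2, `CCCS(=O)(=O)Nc1ccc(F)c(C(=O)c2n[nH]c3ncc(-c4ccc(C(=O)O)cc4)cc23)c1F`, gives 0.2%

Compound 2 stands at the lowest of the two numbers, yet its gap to compound 1 lies within the scatter, so no order between them can be read. Compound 3, `CCCS(=O)(=O)Nc1ccc(F)c(C(=O)c2n[nH]c3ncc(-c4ccc(C(N)=O)cc4)cc23)c1F`, differs from compound 2 by amino in place of hydroxy on a carbonyl carbon. Among the compounds with values here, the only measured step, a number 4.9 percentage points lower from compound 1 to compound 2 (within the scatter), is the sole guide, and it stayed within the scatter; no step beyond the scatter is expected from compound 2 to compound 3 either. Compound 3 is therefore estimated at 2.5%, with a range from 0% to 12%. This estimate means a step of a number 2.3 percentage points higher from compound 2 to compound 3 (within the scatter), expected to remain within the scatter.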

Compound 3, a percentage reported as activity, at one concentration (the size of the read-out at that concentration, not a potency): 4%
Beside the measured number, compound 3's estimate is 1.5 percentage points below it; low and high end bracket the measured number.
By their numbers in this assay, from the lowest: compounds 2, 3 and 1 (each within the scatter of the next).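

In this assay, amino in place of hydroxy on the carbonyl carbon gives a number 3.8 percentage points higher from compound 2 to compound 3 (within the scatter) and carbamoyl in place of sulfamoyl gives a number 1.1 percentage points lower from compound 1 to compound 3 (within the scatter) on the same aromatic carbon. Carbamoyl thus joins carboxy and sulfamoyl as a third group at this place, and no step among the three goes beyond the scatter.

From the compounds shown here alone, whether a nitrile, a methyl ester or an amine at this place would stay within the scatter remains open. No evidence at hand gives a reason for these results.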